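The source may hold more compounds than are shown below. What is called first, only, known or untested is meant among the compounds shown, and "the series" means these compounds.

Compound 1 `CC(C)OC(=O)N1CCC(Oc2ncnc3c2CCN3c2ccc(S(C)(=O)=O)cc2)CC1`: 126 nM
Compound 2 `CC(C)OC(=O)N1CCC(Oc2ncnc3c2CCN3c2ccc(C#N)cc2F)CC1`: 63.1 nM

Of the compounds shown here, two have been tested in a functional assay on CHO-K1 cells for agonist activity at Glucose-dependent insulinotropic receptor (Homo sapiens), read by a luciferase reporter, with a stated time of 5 h; a lower number here means that less compound is needed, a higher number that more compound is needed for the effect. Compound 1 gives 126 nM in this assay, and compound 2 gives 63.1 nM. Going by the values given here, the single measured step between them, a 2.0-fold lower number from compound 1 to compound 2 (0.30 log units; within the scatter), lies within the scatter, so compound 2 stands at the lower of the two numbers without being separable from compound 1.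

Compound 3 `CC(C)OC(=O)N1CCC(Oc2ncnc3c2CCN3c2ccc(S(C)(=O)=O)nc2)CC1` differs from compound 2 in one place: 6-(methylsulfonyl)pyridin-3-yl in place of 4-cyano-2-fluorophenyl on a nitrogen on an aromatic ring in a ring. The methylsulfonyl group that compound 1 carries thus returns, while the ring that bears it now holds a nitrogen. Among the compounds with values here, the only step that bears on this change is a 2.0-fold lower number from compound 1 to compound 2 (0.30 log units; within the scatter), and running it backwards would return the number to that of compound 1; no measured pair speaks to the ring nitrogen on its own. The writer therefore expects for compound 3 a step of a 1.7-fold higher number from compound 2 to compound 3 (0.24 log units; within the scatter), that is, no step beyond the scatter. The estimate for compound 3 in this assay is 110 nM, with a range from 40 nM to 320 nM.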

Compound 3, half-maximal effective concentration: 251 nM
For compound 3 the middle estimate is 2.3-fold (0.36 log units) below the measured one; measured number inside the range.
By their numbers in this assay, from the lowest: compounds 2, 1 and 3 (each within the scatter of the next, the first and the last beyond it).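

In this assay, going by these compounds alone, the group on this nitrogen now produces a separation that the first pair of compounds did not: a 4.0-fold higher number from compound 2 to compound 3 (0.60 log units; beyond the scatter) is a modest step beyond the scatter, so 4-cyano-2-fluorophenyl and 6-(methylsulfonyl)pyridin-3-yl can be told apart at this position. The ring nitrogen, the one difference between the 4-(methylsulfonyl)phenyl of compound 1 and the 6-(methylsulfonyl)pyridin-3-yl of compound 3, gives no separation here: a 2.0-fold higher number from compound 1 to compound 3 (0.30 log units; within the scatter) stays within the scatter. Nothing available explains why these steps have the sizes they do.

Which part of the change carries the step from compound 2 to compound 3 stays open, as the nitrile, the fluorine and the methylsulfonyl group all change together in that pair. Also open, going by these compounds, is how the number responds to other groups on this aromatic ring, such as a plain 4-cyanophenyl, a pyridine ring bearing a nitrile, an amine or a carboxylic acid.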